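This account rests on a few compounds, and the source may have more. Where it says the series, first, only, none or still open, it means among the compounds named here.

In a functional assay on DU-145 cells (Homo sapiens) for inhibition, read by trypan blue exclusion, with a stated time of 96 h (on this read-out higher numbers stand for weaker inhibition of growth and lower numbers for stronger inhibition of growth), compound 1 `O=C(/C(=C\c1ccc(O)c([N+](=O)[O-])c1)SCc1ccc(Br)cc1)c1c(F)c(F)c(F)c(F)c1F` gives 10000 nM and compound 2 `O=C(/C(=C\c1ccc(O)c(Br)c1)Sc1ccc(Br)cc1)c1c(F)c(F)c(F)c(F)c1F` gives 1000 nM as the lower of the two numbers, which means stronger inhibition of growth. Compound 3 `O=C(/C(=C\c1ccc(O)c([N+](=O)[O-])c1)Sc1ccc(Br)cc1)c1c(F)c(F)c(F)c(F)c1F` has nitro in place of bromo on an aromatic carbon of compound 2, ortho to a hydroxy group (nitro in place of bromo on an aromatic carbon). Compound 1 also carries nitro and gives 10000 nM but differs from compound 2 elsewhere too, so it is only a loose guide. A modest move towards weaker inhibition is expected (a 2.0-fold higher number from compound 2 to compound 3 (0.30 log units; within the scatter)). For compound 3 the estimate is 2000 nM (500 nM to 8000 nM).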

Compound 3, concentration for 50% growth inhibition: 1000 nM
Estimate against measurement, compound 3: 2.0-fold (0.30 log units) above; the range from low to high includes it.
By their numbers in this assay, from the lowest: compounds 2 and 3 (each within the scatter of the next); then compound 1.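

In this assay, the position ortho to a hydroxy group accepts either bromo or nitro, with no change at the digits printed from compound 2 to compound 3 (within the scatter). With nitro kept in place, the group on sulfur matters: 4-bromophenyl in place of 4-bromobenzyl gives a 10-fold lower number from compound 1 to compound 3 (1.00 log units; beyond the scatter), so nitro alone does not account for the high number of compound 1. Nothing available gives a reason for either step. Still open, on these data alone, is whether an amine or a carboxylic acid at this position would give a similar number, and how a longer chain on sulfur would behave.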